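The compounds below may be only part of what the source reports. "The series", "measured", "known", "first", "only" and "open" are said of these compounds alone.

Three compounds sharing one core have been measured in a functional assay on HEK293 cells for antagonist activity at proteinase-activated receptor 4 (Homo sapiens), read by FLIPR and calcium flux, with a stated time of 30 min; on this read-out lower numbers stand for stronger inhibition and higher numbers for weaker inhibition:

Compound 1 `CCOc1nn2cc(-c3cc4ccccc4o3)nc2s1` gives 67 nM
Compound 2 `COc1nn2cc(-c3cc4ccccc4o3)nc2s1` gives 4 nM
Compound 3 `CS(=O)(=O)c1nn2cc(-c3cc4ccccc4o3)nc2s1` gives 820 nM

Compound 2 stands lowest of the three, and both gaps to it lie beyond the scatter: a 17-fold lower number from compound 1 to compound 2 (1.22 log units; beyond the scatter) and a 210-fold higher number from compound 2 to compound 3 (2.31 log units; beyond the scatter). Every measured step, including a 12-fold higher number from compound 1 to compound 3 (1.09 log units; beyond the scatter), changes the group on the aromatic carbon of the small core ring. The next compound, compound 4 `COc1nn2cc(-c3cc4cccc(OC)c4o3)nc2s1`, keeps the methoxy of compound 2 there and instead alters the other half of the molecule: methoxy in place of hydrogen on an aromatic carbon. Among the compounds with values here, no measured pair touches that ring, so nothing seen so far speaks to this change directly. Without any step at this place to lean on, the expectation is a number close to that of compound 2, with no step beyond the scatter in either direction, but with a wide range to reflect how little is known.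

The estimate for compound 4 in this assay is 6 nM, between 1.5 nM and 25 nM, which is expected to mean a 1.5-fold higher number from compound 2 to compound 4 (0.18 log units; within the scatter).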

Compound 4, half-maximal inhibitory concentration: 2.8 nM
Estimate against measurement, compound 4: 2.1-fold (0.33 log units) above; low and high end bracket the measured number.
By their numbers in this assay, from the lowest: compounds 4 and 2 (each within the scatter of the next); then compound 1; then compound 3.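

On an aromatic carbon of the six-membered aromatic ring of carbon only, ortho to a fused ring and meta to a fused ring, adding a methoxy gives a 1.4-fold lower number from compound 2 to compound 4 (0.15 log units; within the scatter) in this assay. So this is the first measured change in this half of the molecule, and compound 2 and compound 4 cannot be told apart, whereas replacing the methoxy on the other side of the molecule gave a 210-fold higher number from compound 2 to compound 3 (2.31 log units; beyond the scatter). Nothing measured here accounts for how little the number moves with the added methoxy.

Only a methoxy has been seen at this position, so an amine, a carboxylic acid or a longer chain there could give a quite different number. As far as these compounds go, the other carbons of this ring also remain open, as does whether the same methoxy would leave the number unchanged with the ethoxy of compound 1 on the shared core.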